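A few compounds are considered here, and "the series" means these few. Any claim that something is new, unique, unknown or untested is made for them only; others in the source may bear on it.

Measured in a functional assay on the whole organism (strain albino) for inhibition, with Rattus norvegicus as the target, read by paw edema, with stated times of 1 h and 2 h, at a dose of 20 mmol/kg by the intraperitoneal route; on this read-out higher numbers stand for more inhibition at the one dose given (going by the name of the read-out) and lower numbers for less inhibition:
Compound 1 `N#CC1=C(NCC(=O)N2CCCC2)N(c2ccccc2)C(=O)N2CCCCC(N3CCCC3)C12`: 49.8%
Compound 2 `COc1ccc(/C=N/C2=C(C#N)C3C(N4CCCC4)CCCCN3C(=O)N2c2ccccc2)cc1`: 71.6%

Within the data shown here, compound 2 stands highest of the two numbers in this assay; its only neighbour is compound 1, and the step of a number 21.8 percentage points higher from compound 1 to compound 2 (beyond the scatter) lies beyond the scatter. The unmeasured compound 3 `N#CC1=C(NCC(=O)N2CCCCC2)N(c2ccccc2)C(=O)N2CCCCC(N3CCCC3)C12` is reached from compound 2 by a single change: a group of 10 heavy atoms (7 carbon, 2 nitrogen, 1 oxygen; one six-membered non-aromatic ring with 1 hetero atom) in place of a group of 10 heavy atoms (8 carbon, 1 nitrogen, 1 oxygen; one six-membered aromatic ring of carbon only), on a double-bonded ring carbon. Among the measured compounds shown here, this change is, in effect, the one measured step run the other way: the entering group is the same kind of amide-bearing chain that compound 1 carries, differing from it only in its ring, a six-membered non-aromatic ring with 1 hetero atom in place of a five-membered one. For the measured compounds named here, because the only measured guide is a number 21.8 percentage points higher from compound 1 to compound 2 (beyond the scatter), compound 3 is expected to give back most of that gain, a drop beyond the scatter of about a number 19.6 percentage points lower from compound 2 to compound 3 (beyond the scatter). Going by the values given here, no measured pair shows what the ring size of this amide does on its own, so the range is kept wide. Compound 3 is therefore estimated at 52%, between 36% and 68%.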

Compound 3, a percentage reported as inhibition, in the whole organism at one dose (the size of the read-out at that dose, not a potency): 46.1%
Estimate against measurement, compound 3: 5.9 percentage points above, within the range that was stated.
By their numbers in this assay, from the lowest: compounds 3 and 1 (each within the scatter of the next); then compound 2.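

On the double-bonded ring carbon, in this assay, (((piperidin-1-yl)carbonyl)methyl)amino in place of the group carrying the six-membered aromatic ring of carbon only gives a number 25.5 percentage points lower from compound 2 to compound 3 (beyond the scatter), so a gap beyond the scatter now appears with two different amides rather than with compound 1 alone. The ring on the amide carbonyl does not separate the two chain-bearing compounds, since piperidin-1-yl in place of pyrrolidin-1-yl on a carbonyl carbon gives a number 3.7 percentage points lower from compound 1 to compound 3 (within the scatter), and ring size therefore cannot be read as a factor at this dose. Among these three compounds, the group on this ring carbon is thus the only change that moves the number beyond the scatter.

The compounds shown leave open whether morpholin-4-yl or an open-chain diethylamino on the carbonyl carbon would stay level with these two amides, and whether a longer chain between the amino nitrogen and the carbonyl would alter the result. On these data alone, it also remains open whether the methoxy group of compound 2 contributes to its number, as a pair differing only in that group would be needed, and nothing at hand accounts for the gap.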